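Acylsulfonylurea series at the EP3 receptor: aryl sulfonyl replacement

The source may hold more compounds than are shown below. What is called first, only, known or untested is meant among the compounds shown, and "the series" means these compounds.

Working notes on three measured compounds and one awaiting measurement. In an assay on isolated protein for displacement of a labelled ligand from prostaglandin E2 receptor EP3 subtype (Homo sapiens), read by scintillation counting, with a stated time of 2 h (on this read-out lower numbers stand for stronger inhibition and higher numbers for weaker inhibition), compound 1 `COc1ccc(S(=O)(=O)NC(=O)NC/C=C2\CCCc3cnn(Cc4ccc(Cl)cc4Cl)c32)cc1` gives 10 nM. Among the measured compounds shown here, this is the highest number of the three so far. Compound 3 `O=C(NC/C(F)=C1\CCCc2cnn(Cc3ccc(C(F)(F)F)cc3)c21)NS(=O)(=O)c1cc(Cl)c(Cl)s1` gives 7 nM in this assay, which lies within the scatter of compound 1, so no order between the two can be read. Compound 2 `CS(=O)(=O)c1ccc(-n2ncc3c2/C(=C/CNC(=O)NS(=O)(=O)c2cc(Cl)c(Cl)s2)CCC3)cc1` gives 1 nM in this assay, a gap from compound 1 that is beyond the scatter; compound 2 differs from compound 1 in more than one place, so the gap is not assigned to any single change.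

Compound 4 `Cn1cc(S(=O)(=O)NC(=O)NC/C=C2\CCCc3cnn(Cc4ccc(Cl)cc4Cl)c32)cn1` is the next step from compound 1: 1-methyl-1H-pyrazol-4-yl in place of 4-methoxyphenyl on a sulfonyl sulfur. For the measured compounds named here, no measured pair in the set shows this exchange, so the size of the step rests on expectation alone. The step from compound 1 to compound 4 is expected to be modest and toward weaker binding, a 3.0-fold higher number from compound 1 to compound 4 (0.48 log units; beyond the scatter), since nothing in the measured compounds speaks for a gain. Compound 4 is estimated at 30 nM in this assay, with a range from 8 nM to 120 nM.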

Compound 4, inhibition constant: 9 nM
Compound 4: the middle estimate sits 3.3-fold (0.52 log units) above what was measured; measured number inside the range.
By their numbers in this assay, from the lowest: compound 2; then compounds 3, 4 and 1 (each within the scatter of the next).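

In this assay, among the compounds shown here, 1-methyl-1H-pyrazol-4-yl in place of 4-methoxyphenyl on a sulfonyl sulfur gives a 1.1-fold lower number from compound 1 to compound 4 (0.05 log units; within the scatter) and is the first single-place comparison. On the core of compound 1, this position therefore takes a five-membered aromatic ring with 2 hetero atoms in place of a six-membered aromatic ring of carbon only, with no change that can be read in binding. No supporting data bear on why the number holds across this exchange.

On these data alone, it remains open whether the same position also accepts a non-aromatic group such as cyclopropyl, or an aromatic ring carrying a carboxylic acid. As far as these compounds go, it also remains open whether 1-methyl-1H-pyrazol-4-yl would hold up the same way on the different scaffolds of compound 2 and compound 3.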